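Cyclopentyl Amide in Human Liver Microsomes

The source may hold more compounds than are shown below. What is called first, only, known or untested is meant among the compounds shown, and "the series" means these compounds.

Compound 3 `Cc1cc(NC(=O)[C@H]2CN(C)C[C@@H]2c2ccc(/C=C/C(=O)Nc3ccccc3N)cc2)ccc1F` shows the highest number of the three measured compounds in an in vitro ADME assay on microsomes from liver (Homo sapiens) for pharmacokinetics, read by LC-MS, with a stated time of 10 min, tested at 1 uM (a lower number here means slower removal, a higher number faster removal of the compound), with 15 mL/min/kg, yet the gap to compound 2 `Cc1cccc(NC(=O)[C@H]2CN(C)C[C@@H]2c2ccc(/C=C/C(=O)Nc3ccccc3N)cc2)c1`, which gives 14 mL/min/kg, is a 1.1-fold higher number from compound 2 to compound 3 (0.03 log units; within the scatter), so no order between those two can be claimed. Compound 1 `CN1C[C@H](C(=O)Nc2ccc(Br)cc2)[C@@H](c2ccc(/C=C/C(=O)Nc3ccccc3N)cc2)C1` gives 3 mL/min/kg, and the steps of a 4.7-fold higher number from compound 1 to compound 2 (0.67 log units; beyond the scatter) and a 5.0-fold higher number from compound 1 to compound 3 (0.70 log units; beyond the scatter) are the only movements beyond the scatter seen so far.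

Compound 4 `CN1C[C@H](C(=O)NC2CCCC2)[C@@H](c2ccc(/C=C/C(=O)Nc3ccccc3N)cc2)C1` differs from compound 3 by cyclopentyl in place of 4-fluoro-3-methylphenyl on an amide-type nitrogen. Among the compounds with values here, none of the measured steps bears directly on this change: the two steps beyond the scatter swap one substituted phenyl for another on the same amide-type nitrogen, and the one step within the scatter adds a fluoro on an aromatic carbon. Only the region of the molecule is shared with the measured steps, not the kind of change.

With the measured steps mute on an aryl-to-cycloalkyl exchange, the expected step is a 1.5-fold lower number from compound 3 to compound 4 (0.18 log units; within the scatter), which is best read as no confident direction and a wide range. Compound 4 is therefore estimated at 10 mL/min/kg in this assay, between 4 mL/min/kg and 28 mL/min/kg.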

Compound 4, clearance: 9 mL/min/kg
Beside the measured number, compound 4's estimate is 1.1-fold (0.05 log units) above it, within the range that was stated.
By their numbers in this assay, from the lowest: compound 1; then compounds 4, 2 and 3 (each within the scatter of the next).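

In this assay, the cyclopentyl amide shows that an aromatic ring on this amide-type nitrogen is not required for the number to stay where the two methylphenyl amides stand: a 1.7-fold lower number from compound 3 to compound 4 (0.22 log units; within the scatter) and a 1.6-fold lower number from compound 2 to compound 4 (0.19 log units; within the scatter), so exchanging either aryl group for a non-aromatic ring of carbon gives no readable change. Only the 4-bromophenyl amide stands apart, with a 3.0-fold higher number from compound 1 to compound 4 (0.48 log units; beyond the scatter), so among these four amides the low number belongs to that one group, and the 3-methylphenyl and 4-fluoro-3-methylphenyl amides, though also aryl, do not share it. Nothing at hand speaks to the reason for any of these numbers.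

As far as these compounds go, it remains open whether a 4-chlorophenyl or an unsubstituted phenyl group on this nitrogen would read with the 4-bromophenyl amide or with the other three. Also open, from the compounds shown here alone, is how a cyclopropyl or cyclohexyl ring, an open chain such as tert-butyl, or a cyclopentyl ring carrying an amine would read in this assay.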